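Amide nitrogen substituents on a dimethoxy tetralin acetamide series

The source may hold more compounds than are shown below. What is called first, only, known or untested is meant among the compounds shown, and "the series" means these compounds.

Measured in a functional assay on the whole organism (strain Swiss albino) for inhibition, with Mus musculus as the target, in the writhing test, with stated times of 60 min and 15 min, at a dose of 100 mg/kg by the oral route; on this read-out lower numbers stand for less inhibition and higher numbers for more inhibition at the one dose given (going by the name of the read-out):
compound 1 `COc1cc2c(cc1OC)C(CC(N)=O)CC2`: 24.6%
compound 2 `COc1cc2c(cc1OC)C(CC(=O)NC(C)C)CC2`: 29.3%
compound 3 `CCCCCNC(=O)CC1CCc2cc(OC)c(OC)cc21`: 71.7%

Compound 3 stands highest of the three numbers in this assay; its nearest neighbour is compound 2, and the gap to it as well as to compound 1 lies beyond the scatter. Compound 4 `COc1cc2c(cc1OC)C(CC(=O)NC1CCCC1)CC2` differs from compound 3 in one place: cyclopentyl in place of pentyl on an amide-type nitrogen.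

For the measured compounds named here, the steps that bear on this change are the ones in which the group on the amide-type nitrogen was varied. Replacing hydrogen by isopropyl gave a number 4.7 percentage points higher from compound 1 to compound 2 (within the scatter). Replacing hydrogen by pentyl gave a number 47.1 percentage points higher from compound 1 to compound 3 (beyond the scatter), and replacing isopropyl by pentyl gave a number 42.4 percentage points higher from compound 2 to compound 3 (beyond the scatter). The series therefore shows that a five-carbon chain on this nitrogen raised the number strongly, while a branched three-carbon group did not. Going by the values given here, no measured step compares a ring against a chain of the same carbon count, so the effect of closing the five carbons into a ring cannot be read directly from the data. Cyclopentyl shares the carbon count of pentyl but, like isopropyl, is branched at the carbon bonded to nitrogen.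

Compound 4 is therefore expected to lie below compound 3, with a step of a number 21.7 percentage points lower from compound 3 to compound 4 (beyond the scatter) in this assay, though the uncertainty is wide. The estimate for compound 4 is 50%, in the range 25% to 75%.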

Compound 4, a percentage reported as inhibition, in the whole organism at one dose (the size of the read-out at that dose, not a potency): 37%
Estimate against measurement, compound 4: 13 percentage points above; measured number inside the range.
By their numbers in this assay, from the lowest: compounds 1, 2 and 4 (each within the scatter of the next, the first and the last beyond it); then compound 3.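

In this assay, cyclopentyl in place of pentyl on the amide-type nitrogen gave a number 34.7 percentage points lower from compound 3 to compound 4 (beyond the scatter) and so, with both groups holding the same count of carbon atoms, the count alone does not account for the number of compound 3. Set against the other groups, cyclopentyl gave a number 7.7 percentage points higher from compound 2 to compound 4 (within the scatter) and also a number 12.4 percentage points higher from compound 1 to compound 4 (beyond the scatter) so the ring falls with isopropyl rather than with pentyl, while its number stands clear of the hydrogen of compound 1 but not of the isopropyl of compound 2. Among these four compounds, only the open pentyl chain reaches the high number, and nothing at hand bears on why the ring and the chain part so widely.

Going by these compounds, whether that high number depends on chain length, or on the absence of branching, remains open, and butyl, hexyl, a longer chain or a branched five-carbon group such as isopentyl on this nitrogen would separate the two readings. Also open, on these data alone, are cyclohexyl, which would show whether ring size matters, and a pentyl chain ending in an amine or a carboxylic acid, which would test how far the end of the chain can be changed.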